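Working notes: from compound 1 to compound 3

This account rests on a few compounds, and the source may have more. Where it says the series, first, only, none or still open, it means among the compounds named here.

- compound 1 `COc1cc(NC(C)CCCNC(=O)NNC(=O)Nc2ccc(Cl)c(C(F)(F)F)c2)c2ncccc2c1`: 14000 nM
- compound 2 `COc1ccc(/C(=N/NC(=O)NCCCC(C)Nc2cc(OC)cc3cccnc23)c2ccccc2)cc1`: 10000 nM

In a functional assay on CCRF-CEM cells (Homo sapiens) for inhibition, read by MTT assay, with a stated time of 4 days (on this read-out higher numbers stand for weaker inhibition and lower numbers for stronger inhibition), compound 1 gives 14000 nM, within the scatter of compound 2 at 10000 nM. Compound 3 `COc1cc(NC(C)CCCNC(=O)NNC(=O)NC(CO)(CO)CO)c2ncccc2c1` has 2-hydroxy-1,1-bis(hydroxymethyl)ethyl in place of 4-chloro-3-(trifluoromethyl)phenyl on an amide-type nitrogen. Among the compounds with values here, no measured pair shows this exchange, so the expectation rests on the structural change alone. The expected step is a 2.9-fold higher number from compound 1 to compound 3 (0.46 log units; beyond the scatter), towards weaker inhibition and beyond the scatter. For compound 3 the estimated value is 40000 nM, with an expected range of 12000 nM to 120000 nM.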

Compound 3, half-maximal inhibitory concentration: > 250000 nM
Compound 3: a limit, no number; the forecaster's own chance of this, stated with the estimate: 35%; at least 6.2-fold (0.79 log units) between middle value and limit.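

On the amide-type nitrogen, 2-hydroxy-1,1-bis(hydroxymethyl)ethyl in place of 4-chloro-3-(trifluoromethyl)phenyl gives, in this assay, an at least 17-fold higher number from compound 1 to compound 3 (1.25 log units; beyond the scatter). The reading for compound 3 is a limit of the assay, not a number: the limit of > 250000 nM in this assay, at which 1 of the 3 values shown sits.

Within the data shown here, compound 1 and compound 2 offered no exchange at this place, so this is the first step showing that the read-out depends on the group on this nitrogen.

On these data alone, the exact size of the step stays open. So does whether it follows from losing the aromatic ring or from gaining the hydroxyl groups; a plain phenyl or a tert-butyl group on the same nitrogen would separate the two.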